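Trimming an Aryl Ring Down to a Nitrile

A few compounds are considered here, and "the series" means these few. Any claim that something is new, unique, unknown or untested is made for them only; others in the source may bear on it.

Compound 1 `Cc1n[nH]c(C(=O)O)c1Cc1cccc(-c2cccc(F)c2)c1` was tested in an assay on isolated protein for inhibition of 2-Hydroxyacid oxidase 2 (Rattus norvegicus) (on this read-out higher numbers stand for weaker inhibition and lower numbers for stronger inhibition), and gives 500 nM. Two relatives carry the same acid-bearing core. Compound 2 `Cc1n[nH]c(C(=O)O)c1Cc1ccc(Oc2ccccc2)cc1` in this assay gives 500 nM, and compound 3 `CC(C)c1n[nH]c(C(=O)O)c1Cc1cccc(-c2ccc(F)cc2)c1` in this assay gives 500 nM. At the digits reported, compound 1 stands level with both; its nearest neighbour is compound 2 and its furthest is compound 3, yet neither gap reaches beyond the usual scatter, so no order among the three can be read from these numbers.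

The next compound, compound 4 `Cc1n[nH]c(C(=O)O)c1Cc1cccc(C#N)c1`, differs from compound 1 in one place: cyano in place of 3-fluorophenyl on an aromatic carbon. The whole second aromatic ring is removed and a far smaller group takes its place on the same aromatic carbon. Among the measured compounds shown here, no pair of measured compounds shows such a change, so its size is untested here. As far as these compounds go, compound 1, compound 2 and compound 3 each keep a second aromatic ring and each sit at the same reading; what happens when that ring is cut away is unknown. Given that every measured compound retains such a ring, the step of a 6.0-fold higher number from compound 1 to compound 4 (0.78 log units; beyond the scatter) is expected to lie beyond the scatter toward weaker inhibition. Compound 4 is therefore estimated at 3000 nM, with a range from 800 nM to 15000 nM.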

Compound 4, half-maximal inhibitory concentration: 500 nM
Compound 4: the middle estimate sits 6.0-fold (0.78 log units) above what was measured; measured number outside the range, below it.
By their numbers in this assay, from the lowest: compounds 1, 2, 3 and 4 (each within the scatter of the next).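

In this assay the exchange of 3-fluorophenyl for cyano on an aromatic carbon gives no change at the digits printed from compound 1 to compound 4 (within the scatter). The earlier compounds shown here all carried a second aromatic ring, so they could not show what its loss would do; this pair shows that, on this carbon of the core of compound 1, the ring can give way to a much smaller group with no change in the reading. Nothing available explains why the reading holds across this exchange.

As far as these compounds go, it remains open whether the nitrile itself matters at this carbon, or whether a plain hydrogen, a methyl group, a chlorine atom or a methoxy group would give the same reading in this assay. From the compounds shown here alone, it is also open whether the same trimming would hold with an ethyl group or a longer chain in place of the methyl group on the shared core, and whether any group on this carbon can move the reading at all.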